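The compounds below may be only part of what the source reports. "The series", "measured", "known", "first", "only" and "open" are said of these compounds alone.

Of the compounds shown here, three built on one shared core have been tested in an ADME assay on NIH3T3 cells (Mus musculus) for cytotoxicity, read by MTT assay; on this read-out lower numbers stand for stronger inhibition and higher numbers for weaker inhibition. Compound 1 `N#Cc1c(-c2cccc(Cl)c2)c(C#N)c(=O)n(/N=C/c2cn(-c3ccccc3)nc2-c2ccccc2)c1N` gives 52 ug/mL, compound 2 `Cc1ccc(-c2c(C#N)c(N)n(/N=C/c3cn(-c4ccccc4)nc3-c3ccccc3)c(=O)c2C#N)cc1` gives 98 ug/mL, and compound 3 `N#Cc1c(-c2ccccc2Br)c(C#N)c(=O)n(/N=C/c2cn(-c3ccccc3)nc2-c2ccccc2)c1N` gives 174 ug/mL. Compound 3 thus carries the highest of the three numbers, though its step from compound 2 is a 1.8-fold higher number from compound 2 to compound 3 (0.25 log units; within the scatter), while its step from compound 1 is a 3.3-fold higher number from compound 1 to compound 3 (0.52 log units; beyond the scatter), a modest but real gap.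

The next compound, compound 4 `N#Cc1c(-c2ccccc2C(F)(F)F)c(C#N)c(=O)n(/N=C/c2cn(-c3ccccc3)nc2-c2ccccc2)c1N`, is reached from compound 3 by a single change: trifluoromethyl in place of bromo on an aromatic carbon. Going by the values given here, no measured step exchanges exactly these two groups, so the bearing of the earlier results is indirect. What they show is that replacing one aromatic substituent by another at this position has shifted this assay only modestly at most, as in a 1.9-fold higher number from compound 1 to compound 2 (0.28 log units; within the scatter) and a 3.3-fold higher number from compound 1 to compound 3 (0.52 log units; beyond the scatter), and that compound 3 already stands at the upper end of the three numbers.

On that basis compound 4 is expected to stay close to compound 3, with a step of a 1.2-fold lower number from compound 3 to compound 4 (0.06 log units; within the scatter) that should not exceed the usual scatter. The estimate for compound 4 in this assay is therefore 150 ug/mL, with a plausible range from 70 ug/mL to 330 ug/mL.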

Compound 4, half-maximal inhibitory concentration: 56 ug/mL
For compound 4 the middle estimate is 2.7-fold (0.43 log units) above the measured one; measured number outside the range, below it.
By their numbers in this assay, from the lowest: compounds 1, 4, 2 and 3 (each within the scatter of the next, the first and the last beyond it).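

In this assay, the exchange of bromo for trifluoromethyl leaves the substituent on the same aromatic carbon, ortho to a large group, and still gives a step beyond the scatter, a 3.1-fold lower number from compound 3 to compound 4 (0.49 log units; beyond the scatter), so the identity of the group at this place counts, not only where it sits on the ring. Compound 3 alone might have suggested that a substituent at this place goes with a high number, but compound 4 goes against that reading: its steps from the two compounds substituted elsewhere on the ring, a 1.8-fold lower number from compound 2 to compound 4 (0.24 log units; within the scatter) and a 1.1-fold higher number from compound 1 to compound 4 (0.03 log units; within the scatter), both lie within the scatter. Nothing measured here offers a reason for the gap between the 2-bromophenyl and 2-(trifluoromethyl)phenyl compounds.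

The compounds shown leave open how an amine, a carboxylic acid or a longer alkyl chain on this same carbon would read in this assay, and so whether bromo or trifluoromethyl is the unusual case. Equally open, going by these compounds, is whether these two groups would differ in the same way on another carbon of that ring.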